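The compounds below may be only part of what the source reports. "The series", "measured", "known", "first", "only" and "open" are said of these compounds alone.

In a functional assay on PC-3 cells (Homo sapiens) for antiproliferative activity, read by MTT assay, with a stated time of 72 h (on this read-out lower numbers stand for stronger inhibition and higher numbers for weaker inhibition), compound 1 (`O=C(N/N=C/c1ccccc1)Nc1ccc(Oc2ccnc3[nH]ccc23)c(F)c1`) gives 7940 nM while compound 2 (`O=C(N/N=C/c1cc(Br)c(O)c(Br)c1)Nc1ccc(Oc2ccnc3[nH]ccc23)c(F)c1`) is reported as "not active" (no number reported) and so stands without a single number. Compound 3 (`CN(C)CCn1cccc1/C=N/NC(=O)Nc1ccc(Oc2ccnc3[nH]ccc23)c(F)c1`) has not yet been measured. It carries 1-(2-(dimethylamino)ethyl)-1H-pyrrol-2-yl in place of the 3,5-dibromo-4-hydroxyphenyl of compound 2 (1-(2-(dimethylamino)ethyl)-1H-pyrrol-2-yl in place of 3,5-dibromo-4-hydroxyphenyl on a carbon with a double bond to nitrogen) on a carbon with a double bond to nitrogen. Among the compounds with values here, no measured step covers this exchange, so its size is uncertain. In this assay a move toward stronger inhibition is expected, from no number to one near compound 1 at 7940 nM on this read-out. For compound 3 the estimated value is 4000 nM with an expected range from 800 nM to 20000 nM in this measurement.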

Compound 3, half-maximal inhibitory concentration: 1600 nM
Estimate against measurement, compound 3: 2.5-fold (0.40 log units) above; measured number inside the range.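

In this assay, the place on a carbon with a double bond to nitrogen now has one readable step: 1-(2-(dimethylamino)ethyl)-1H-pyrrol-2-yl in place of phenyl gives a 5.0-fold lower number from compound 1 to compound 3 (0.70 log units; beyond the scatter), a modest move toward stronger inhibition that lies beyond the scatter. The step from compound 2 cannot be read, as compound 2 has no number. No measurement here bears on why the number moved.

The compounds shown leave open whether the five-membered ring or the dimethylaminoethyl chain accounts for the step. They also leave open how a morpholine in place of the dimethylamino group would read.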